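A few compounds are considered here, and "the series" means these few. Any claim that something is new, unique, unknown or untested is made for them only; others in the source may bear on it.

In a physicochemical assay for solubility, in phosphate buffer, with a stated time of 18 h (a lower number here means a less soluble compound, a higher number a more soluble compound), three compounds have been measured so far: compound 1 `Cc1ncc2c(N)c(C#N)c(N)nc2n1` gives 783000 nM, compound 2 `N#Cc1c(N)nc2nc(C3CCCC3)ncc2c1N` gives 89000 nM, and compound 3 `Cc1nc(C(C)(C)C)nc2nc(N)c(C#N)c(N)c12` gives 37000 nM, the lowest of the three numbers. The next structure is compound 4 `CC(C)(C)c1nc(CCCCCC#N)c2c(N)c(C#N)c(N)nc2n1`, which has not yet been measured. The change is 4-cyanobutyl in place of hydrogen on a saturated chain carbon bound to an aromatic carbon, so that a methyl becomes a 5-cyanopentyl.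

For the measured compounds named here, only one measured step bears on this: an 8.8-fold lower number from compound 1 to compound 2 (0.94 log units; beyond the scatter), a modest drop beyond the scatter, in which cyclopentyl replaced methyl. There the new group was a ring, whereas the group entering here has no ring, and a single step is a loose guide. A fall of similar or somewhat smaller size in this assay is therefore expected, still beyond the scatter. The expected change is a 3.1-fold lower number from compound 3 to compound 4 (0.49 log units; beyond the scatter). The estimate for compound 4 is 12000 nM, with an expected range from 3000 nM to 40000 nM.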

Compound 4, solubility: 6000 nM
Compound 4: the middle estimate sits 2.0-fold (0.30 log units) above what was measured; low and high end bracket the measured number.
By their numbers in this assay, from the lowest: compound 4; then compound 3; then compound 2; then compound 1.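

In this assay, the methyl on this saturated chain carbon's position is open to change, and turning it into a 5-cyanopentyl gives a 6.2-fold lower number from compound 3 to compound 4 (0.79 log units; beyond the scatter) and so a clear fall beyond the scatter. For the compounds shown here, this is the first measured change at this place, and it shows that a group with no ring lowers the number as well, since the only earlier step, an 8.8-fold lower number from compound 1 to compound 2 (0.94 log units; beyond the scatter), brought in the ring of cyclopentyl at a different place. No measurement shown here accounts for either fall.

The compounds shown leave open whether the chain length or the nitrile at its end goes with the fall, as the two arrive together in a single change. A plain pentyl chain, a shorter chain such as ethyl, or a chain ending in an amine or a carboxylic acid would help separate these.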